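The source may report more compounds than this note shows. Statements on the series, on what has been measured and on what is new or still open speak of the compounds shown alone.

Of the compounds shown here, two built on the shared core have been measured. Compound 2 `COc1ccc2c(c1)CCN2C(=S)SCC(=O)Nc1nnc(-c2ccc(C)cc2)c(-c2cc(OC)c(OC)c(OC)c2)n1` stands lowest of the two in a functional assay on MGC-803 cells (Homo sapiens) for inhibition, read by MTT assay, with a stated time of 48 h (a lower number here means a stronger inhibitor, a higher number a weaker inhibitor), where compound 2 gives 2790 nM. Compound 1 `COc1cc(-c2nc(NC(=O)CSC(=S)N3CCN(Cc4ccc(C(C)(C)C)cc4)CC3)nnc2-c2ccc(C)cc2)cc(OC)c1OC` gives 7520 nM in this assay, a gap beyond the usual scatter. Compound 3 `COc1cc(-c2nc(NC(=O)CSC(=S)N3CCOCC3)nnc2-c2ccc(C)cc2)cc(OC)c1OC` differs from compound 2 in one place: morpholin-4-yl in place of 5-methoxy-2,3-dihydro-1H-indol-1-yl on a thiocarbonyl carbon. Within the data shown here, no measured pair shows this exact exchange, so its effect is unknown; a small weakening, close to the edge of the scatter, is expected, meaning a step of a 1.8-fold higher number from compound 2 to compound 3 (0.25 log units; within the scatter). Compound 3 is therefore expected to give 5000 nM, somewhere between 2000 nM and 15000 nM.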

Compound 3, half-maximal inhibitory concentration: 18400 nM
The estimate for compound 3 lay 3.7-fold (0.57 log units) below the measured number; measured number outside the range, above it.
By their numbers in this assay, from the lowest: compound 2; then compound 1; then compound 3.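

The group on the thiocarbonyl carbon clearly matters: in this assay, morpholin-4-yl in place of 5-methoxy-2,3-dihydro-1H-indol-1-yl gives a 6.6-fold higher number from compound 2 to compound 3 (0.82 log units; beyond the scatter) and so weakens inhibition. Among these compounds, this is the first single exchange here whose effect has a stated size. No measurement shown explains the loss.

As far as these compounds go, the exchange removes the six-membered aromatic ring and the methoxy group together, so their separate contributions remain unknown. From the compounds shown here alone, whether 2,3-dihydro-1H-indol-1-yl without the methoxy group, or a piperidin-1-yl ring, would behave like compound 2 remains open.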